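The source may report more compounds than this note shows. Statements on the series, on what has been measured and on what is new or still open speak of the compounds shown alone.

Measured compounds:
- compound 1, `Cc1cccc(S(=O)(=O)Nc2ccc(-c3ccc(CO)cc3)cc2)c1`: < 10% in an assay for binding affinity to 17-beta-hydroxysteroid dehydrogenase type 1 (Homo sapiens), with a stated time of 20 min, tested at 1 uM; a higher number here means more inhibition at the concentration tested (going by the name of the read-out), a lower number less inhibition
- compound 2, `CS(=O)(=O)Nc1ccc(-c2ccc(O)cc2)cc1`: < 10% in this assay

Compound 2 stands at a limit of this assay rather than at a number: the value < 10% reported for compound 2 is a limit. The same holds for compound 1, whose value < 10% is also a limit. Within the data shown here, both values therefore sit on (the limit of < 10% in this assay, at which 2 of the 2 values shown sit), and no step between measured compounds can be read off; the two structures differ in more than one place and show only that each stays at the limit.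

The next compound, compound 3, `Cc1cccc(S(=O)(=O)Nc2ccc(-c3ccc(O)cc3)cc2)c1`, carries the change (3-methylphenyl in place of methyl on a sulfonyl sulfur). It thus pairs the hydroxyphenyl end of compound 2 with the sulfonyl substituent of compound 1. With both measured compounds at the limit, the step that the limit leaves unreadable from compound 2 to compound 3 is expected to be none beyond the scatter, most likely ending again at the limit.

Compound 3 is estimated at 8% in this assay, within 0% to 25%.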

Compound 3, a percentage reported as inhibition, at one concentration (the size of the read-out at that concentration, not a potency): < 10%
Compound 3: a limit, no number (the forecaster's own chance of this, stated with the estimate: 70%); the middle value lies beyond the limit too.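

Compound 3 gives < 10% in this assay and that value is a limit. Among these compounds, no step from compound 1 or compound 2 to compound 3 can be read, because all three compounds sit at the same limit: the limit of < 10% in this assay, at which 3 of the 3 values shown sit. The compounds shown leave open whether either swapped group, 3-methylphenyl on the sulfonyl sulfur or hydroxy on the aromatic carbon, affects inhibition at all.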